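The source may report more compounds than this note shows. Statements on the series, on what has been measured and on what is new or still open speak of the compounds shown alone.

Compound 1 `CN1CCC(c2c[nH]c3cnc(NC(=O)c4ccc(F)cc4)cc23)CC1`: 13 nM in an assay for binding affinity to 5-hydroxytryptamine receptor 1F (Homo sapiens), read by radioligand binding; on this read-out higher numbers stand for weaker inhibition and lower numbers for stronger inhibition.
Compound 2 `CC(=O)Nc1cc2c(C3CCN(C)CC3)c[nH]c2cn1`: 210 nM in this assay.
Compound 3 `CN1CCC(c2c[nH]c3ccc(NC(=O)C4CC4)nc23)CC1`: 9.8 nM in this assay.

Compound 3 has the lowest number of the three, but its gap to compound 1 lies within the scatter, so these two cannot be told apart; only compound 2 stands clearly apart from both. Compound 4 `CN1CCC(c2c[nH]c3ccc(NC(=O)C4CCCCC4)nc23)CC1` has not yet been measured. It differs from compound 3 by cyclohexyl in place of cyclopropyl on a carbonyl carbon. Going by the values given here, the only measured step, a 16-fold higher number from compound 1 to compound 2 (1.21 log units; beyond the scatter), is also a change of the group on the carbonyl carbon, and there the larger group went with the lower number, though that pair sits on a core arranged differently from the core of compound 3. A larger ring in compound 4 might therefore keep the number where it is or lower it somewhat, but with nothing closer to go on, the expected step of a 1.2-fold lower number from compound 3 to compound 4 (0.09 log units; within the scatter) is small and not clearly beyond the scatter. Compound 4 is estimated at 8 nM, with a range from 3 nM to 25 nM in this assay.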

Compound 4, inhibition constant: 20 nM
Compound 4: middle estimate off by 2.5-fold (0.40 log units), on the low side, within the range that was stated.
By their numbers in this assay, from the lowest: compounds 3, 1 and 4 (each within the scatter of the next, the first and the last beyond it); then compound 2.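

In this assay, cyclohexyl in place of cyclopropyl on the carbonyl carbon gives a 2.0-fold higher number from compound 3 to compound 4 (0.31 log units; beyond the scatter) on the core of compound 3, so here the larger ring goes with the higher number, although this modest step only just clears the scatter. The earlier step, a 16-fold higher number from compound 1 to compound 2 (1.21 log units; beyond the scatter) on a differently arranged core, saw the smaller methyl replace 4-fluorophenyl and also gave a higher number, so compound 4 goes against any simple rule that a larger group on this carbonyl carbon lowers the number. No measurement shown here accounts for this difference between the two steps.

Going by these compounds alone, with only two ring sizes on this core, it remains open how the number changes with ring size. A cyclopentyl ring, an open tert-butyl group or a chain carrying an amine at this place could each help to show this.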